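A Swap on Sulfur Where Only Limits Are Known

The source may hold more compounds than are shown below. What is called first, only, known or untested is meant among the compounds shown, and "the series" means these compounds.

Of the compounds shown here, three have been tested so far in a physicochemical assay for solubility (on this read-out lower numbers stand for lower solubility and higher numbers for higher solubility), and none has yielded an exact number. Compound 1 `O=C(O)c1ccc(C(=O)/C(=C\c2ccc([N+](=O)[O-])cc2F)SCc2ccc(Br)cc2)cc1` gives < 1000 ug/mL, which is a limit of the assay and not a measured number. Compound 2 `O=C(O)c1ccc(C(=O)/C(=C\c2ccc(F)c([N+](=O)[O-])c2)Sc2ccc(Br)cc2)cc1` gives < 1000 ug/mL, again only a limit. Compound 3 `O=C(O)c1ccc(C(=O)/C(=C\c2ccc(Cl)c([N+](=O)[O-])c2)S(=O)(=O)Cc2ccc(Br)cc2)cc1` gives < 1000 ug/mL, also a limit. The whole set therefore shows one picture: the limit of < 1000 ug/mL in this assay, at which 3 of the 3 values shown sit. From the compounds shown here alone, compound 2 stands level with the other two on paper, but its true position remains unknown.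

The next compound to be tested is compound 4 `O=C(O)c1ccc(C(=O)/C(=C\c2ccc(F)c([N+](=O)[O-])c2)SCc2ccc(Cl)cc2)cc1`, which differs from compound 2 in one place. The change is 4-chlorobenzyl in place of 4-bromophenyl on a sulfur, with 4-chlorobenzyl in place of 4-bromophenyl on a sulfur. Going by the values given here, no measured pair in this set shows what such a swap does, so the expectation is cautious. Among the compounds with values here, it starts from the limit of compound 2, < 1000 ug/mL, which offers no exact number to step from. The expected step, a step that the limit leaves unreadable from compound 2 to compound 4, is no larger than the usual scatter, with no direction favoured. Most likely, this assay will report only a limit once more. For compound 4 the estimate is 700 ug/mL, with an expected range from 300 ug/mL to 1000 ug/mL.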

Compound 4, solubility: < 1000 ug/mL
Compound 4 was reported as a limit; the forecaster's own chance of this, stated with the estimate: 85%; the middle value does not contradict the limit.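

In this assay compound 4 gives < 1000 ug/mL, which is a limit of the assay and not a number. Going by these compounds alone, compound 2 also carries only a limit, so no step from compound 2 to compound 4 can be read, and the set still shows one picture: the limit of < 1000 ug/mL in this assay, at which 4 of the 4 values shown sit.

The compounds shown leave open where each true value lies, and whether 4-chlorobenzyl in place of 4-bromophenyl on a sulfur moves it in either direction.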